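A Smaller Chloroaryl Amide on a Shared Core

A few compounds are considered here, and "the series" means these few. Any claim that something is new, unique, unknown or untested is made for them only; others in the source may bear on it.

Compound 3 `CN(C)C(=O)c1cc2cnc(Nc3ccc(NC(=O)C4(C(=O)Nc5ccc(Cl)c(C(F)(F)F)c5)CC4)cc3)nc2n1C1CCCC1` is the reference point. In a functional assay on A549 cells (Homo sapiens) for inhibition, read by CCK-8 assay, with a stated time of 72 h, tested at 10 uM (a higher number here means more inhibition of growth at the concentration tested, a lower number less inhibition of growth), compound 3 gives 88.1%, which is the lowest of the three numbers shown, though all three lie within the scatter of one another: compound 1 `CN(C)C(=O)c1cc2cnc(Nc3ccc(NC(=O)C4(C(=O)Nc5ccccc5)CC4)cc3)nc2n1C1CCCC1` gives 88.8% and compound 2 `CN(C)C(=O)c1cc2cnc(Nc3ccc(NC(=O)C4(C(=O)Nc5ccccc5F)CC4)cc3)nc2n1C1CCCC1` gives 88.6%, and the steps of a number 0.7 percentage points lower from compound 1 to compound 3 (within the scatter) and a number 0.5 percentage points lower from compound 2 to compound 3 (within the scatter) are within the scatter, as is a number 0.2 percentage points lower from compound 1 to compound 2 (within the scatter). Compound 4 `CN(C)C(=O)c1cc2cnc(Nc3ccc(NC(=O)C4(C(=O)Nc5cccc(Cl)c5)CC4)cc3)nc2n1C1CCCC1` differs from compound 3 only at the aryl amide: 3-chlorophenyl in place of 4-chloro-3-(trifluoromethyl)phenyl on an amide-type nitrogen. The measured steps that bear on this change are the two earlier exchanges of the aryl group on the same amide-type nitrogen, a number 0.7 percentage points lower from compound 1 to compound 3 (within the scatter) and a number 0.5 percentage points lower from compound 2 to compound 3 (within the scatter), and neither moved the read-out beyond the scatter. A further aryl exchange at this position is therefore expected to leave this assay essentially unchanged, with no step beyond the scatter in either direction. For compound 4 the expected step is a number 0.1 percentage points lower from compound 3 to compound 4 (within the scatter). Compound 4 is thus estimated at 88%, with a range from 80% to 94%.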

Compound 4, percent growth inhibition at one concentration: 90.7%
The estimate for compound 4 lay 2.7 percentage points below the measured number; the range from low to high includes it.
By their numbers in this assay, from the lowest: compounds 3, 2, 1 and 4 (each within the scatter of the next).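

Replacing the aryl group on the amide-type nitrogen with 3-chlorophenyl still produced no step beyond the scatter in this assay (compare a number 2.6 percentage points higher from compound 3 to compound 4 (within the scatter)). The same holds against the 2-fluorophenyl compound (a number 2.1 percentage points higher from compound 2 to compound 4 (within the scatter)). Among these compounds, the one comparison with the unsubstituted phenyl compound (a number 1.9 percentage points higher from compound 1 to compound 4 (within the scatter)) adds that a single chloro in place of hydrogen on this ring also stays within the scatter, so these four aryl groups are not separated by this read-out at the one concentration tested. No measurement shown bears on the cause of these small differences.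

From the compounds shown here alone, what remains open is whether any group on this nitrogen can move the read-out beyond the scatter, such as a phenyl ring carrying a carboxylic acid or a dimethylamino group, a pyridine ring, or a cyclohexyl ring in place of the aryl group.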